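The compounds below may be only part of what the source reports. "The series", "measured", "known", "first", "only" and "open" are said of these compounds alone.

Within the data shown here, in a functional assay on HCT-116 cells (Homo sapiens) for antiproliferative activity, read by MTT assay, with a stated time of 48 h (a higher number here means a weaker inhibitor, a lower number a stronger inhibitor), compound 3 `COc1ccc(CN(C(=O)CSc2nc3ccccc3s2)c2cc(OC)c(OC)c(OC)c2)cc1N=[N+]=[N-]` gives 2860 nM and holds the lowest number of the series so far, while compound 1 `COc1ccc(CN(C(=O)CSc2nc3ccccc3s2)c2cc(OC)c(OC)c(OC)c2)cc1C` gives 17100 nM as the nearest value. Compound 2 `COc1cc(N(Cc2ccc(C)cc2)C(=O)CSc2nc3ccccc3s2)cc(OC)c1OC` stands at > 80000 nM as a limit of the assay and not a number.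

Next comes compound 4 `COc1ccc(CN(C(=O)CSc2nc3ccccc3s2)c2cc(OC)c(OC)c(OC)c2)cc1` with the change hydrogen in place of azido on an aromatic carbon in which hydrogen takes the place of azido on an aromatic carbon. No direct exchange of azido for hydrogen has been measured. Azido in place of methyl gave a 6.0-fold lower number from compound 1 to compound 3 (0.78 log units; beyond the scatter) and is the closest measured step. The wider change to the 3-azido-4-methoxyphenyl group gave an at least 27-fold lower number from compound 2 to compound 3 (1.44 log units; beyond the scatter) but that step rests on a limit. Both compounds without azido sit higher than compound 3.

A modest step to a higher number in this assay is therefore expected, close in size to the step from methyl to azido read in reverse. The expected change is a 5.2-fold higher number from compound 3 to compound 4 (0.72 log units; beyond the scatter) on this estimate. Compound 4 is expected at 15000 nM within an estimated range of 5000 nM to 50000 nM in this series.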

Compound 4, half-maximal inhibitory concentration: 426 nM
For compound 4 the middle estimate is 35-fold (1.55 log units) above the measured one, outside the stated range (below it).
By their numbers in this assay, from the lowest: compound 4; then compound 3; then compound 1. At a limit, above all of these: compound 2.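

In this assay, the aromatic carbon ortho to the methoxy group performs best of the three cases with hydrogen, as both azido (a 6.7-fold lower number from compound 3 to compound 4 (0.83 log units; beyond the scatter)) and methyl (a 40-fold lower number from compound 1 to compound 4 (1.60 log units; beyond the scatter)) give higher numbers. The earlier gain from methyl to azido therefore ranked two substituents against each other and did not show that this position needs a substituent at all. The step with methoxy in place of methyl (an at least 180-fold lower number from compound 2 to compound 4 (2.27 log units; beyond the scatter)) starts from a limit and not from a number: (the limit of > 80000 nM in this assay, at which 1 of the 4 values shown sits).

Still open, as far as these compounds go, is whether a fluorine, a hydroxyl or an amine at this carbon would stay near compound 4 or rise towards compound 3. The compounds shown also cannot tell why azido and methyl both give higher numbers than hydrogen here.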